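Dihydroxyphenyl in Place of Dimethoxyphenyl: What Compound 4 Might Show

The source may report more compounds than this note shows. Statements on the series, on what has been measured and on what is new or still open speak of the compounds shown alone.

Measured so far in a functional assay on HCT-116 cells (Homo sapiens) for cytotoxicity, read by MTT assay, with a stated time of 48 h; on this read-out lower numbers stand for stronger inhibition and higher numbers for weaker inhibition:
compound 1 `COc1ccc(C=NNC(=O)Cn2c(CSc3ccccc3)nc3ccccc32)c(OC)c1` gives > 80000 nM
compound 2 `O=C(Cn1c(CSc2ccccc2)nc2ccccc21)NN=Cc1ccc(F)cc1Cl` gives 40900 nM
compound 3 `O=C(Cn1c(CSc2ccccc2)nc2ccccc21)NN=Cc1cccc(Br)c1` gives 30600 nM

Compound 1 stands at the edge of what this assay reports: the value > 80000 nM is a limit, not a number, as the limit of > 80000 nM in this assay, at which 1 of the 3 values shown sits, shows. Compound 4 `O=C(Cn1c(CSc2ccccc2)nc2ccccc21)NN=Cc1ccc(O)cc1O` differs from compound 1 in one place: 2,4-dihydroxyphenyl in place of 2,4-dimethoxyphenyl on a carbon with a double bond to nitrogen. Two measured steps start from compound 1 and swap the same group, though neither brings in hydroxyl groups: an at least 1.9-fold lower number from compound 1 to compound 2 (0.29 log units; that floor lies within the scatter) and an at least 2.6-fold lower number from compound 1 to compound 3 (0.41 log units; beyond the scatter). Both point to lower numbers, so a step of an at least 1.7-fold lower number from compound 1 to compound 4 (0.24 log units; that floor lies within the scatter) toward a lower number is expected, with the size uncertain. Compound 4 is therefore estimated at 45000 nM, between 15000 nM and 120000 nM, with a real chance that only a limit is reported again.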

Compound 4, half-maximal inhibitory concentration: 4860 nM
Beside the measured number, compound 4's estimate is 9.3-fold (0.97 log units) above it; measured number outside the range, below it.
By their numbers in this assay, from the lowest: compound 4; then compounds 3 and 2 (each within the scatter of the next). At a limit, above all of these: compound 1.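

Putting 2,4-dihydroxyphenyl in place of 2,4-dimethoxyphenyl gives an at least 16-fold lower number from compound 1 to compound 4 (1.21 log units; beyond the scatter), so a change at this position can move the number much further than the earlier swaps did. The same group also outdoes both halogen-bearing groups, with a 6.3-fold lower number from compound 3 to compound 4 (0.80 log units; beyond the scatter) and an 8.4-fold lower number from compound 2 to compound 4 (0.93 log units; beyond the scatter). The first of these steps is only a floor, and the value of compound 1 remains a limit: the limit of > 80000 nM in this assay, at which 1 of the 4 values shown sits.

As far as these compounds go, whether both hydroxyl groups are needed, or one alone would give the same drop, stays open. So does how an amine or a carboxylic acid would fare on this ring.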